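Replacing the ethyl ester chain of compound 3

This account rests on a few compounds, and the source may have more. Where it says the series, first, only, none or still open, it means among the compounds named here.

Measured in an in vitro ADME assay on the whole organism (small intestine) for pharmacokinetics, with Rattus norvegicus as the target (on this read-out higher numbers stand for a longer-lived compound and lower numbers for a shorter-lived compound), so far:
compound 1 `C=CCN(CCCC(=O)O)C(=O)/C(C)=C/c1ccc(C(=O)Oc2ccc(C(=N)N)cc2)cc1` gives 0.917 h
compound 2 `CCOC(=O)CCCN(C(=O)/C(C)=C/c1ccc(C(=O)Oc2ccc(C(=N)N)cc2)cc1)C(C(=O)OCC)C(=O)OCC` gives 1 h
compound 3 `C=CCN(CCCC(=O)OCC)C(=O)/C(C)=C/c1ccc(C(=O)Oc2ccc(C(=N)N)cc2)cc1` gives 1 h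

Compound 3 stands level with compound 2 and within the scatter of compound 1. Compound 4 `C=CCN(CCC(=O)O)C(=O)/C(C)=C/c1ccc(C(=O)Oc2ccc(C(=N)N)cc2)cc1` carries carboxy in place of (ethoxycarbonyl)methyl on a saturated chain carbon, two bonds along the chain from an amide-type nitrogen. Ethyl in place of hydrogen gave a 1.1-fold higher number from compound 1 to compound 3 (0.04 log units; within the scatter) and allyl in place of bis(ethoxycarbonyl)methyl gave no change at the digits printed from compound 2 to compound 3 (within the scatter), both within the scatter. Among the compounds with values here, no measured compound carries the 2-carboxyethyl chain, so the expectation is uncertain. The expected step is a 1.1-fold lower number from compound 3 to compound 4 (0.05 log units; within the scatter), nothing beyond the scatter. For compound 4 the estimate is 0.9 h, with an expected range of 0.5 h to 1.5 h.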

Compound 4, half-life: > 1 h
Compound 4: no number, only a limit (the forecaster's own chance of this, stated with the estimate: 3%); middle value at least 1.1-fold (0.04 log units) from the limit.
By their numbers in this assay, from the lowest: compounds 1, 2 and 3 (each within the scatter of the next).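

In this assay compound 4 gives only a limit, > 1 h, not a number. Carboxy in place of (ethoxycarbonyl)methyl gives a number no lower from compound 3 to compound 4 (the limit leaves the size open). Carboxy in place of carboxymethyl at this place gives an at least 1.0-fold higher number from compound 1 to compound 4 (0.03 log units; that floor lies within the scatter), so the 2-carboxyethyl chain brings no readable loss on this read-out. Compound 4 sits at the limit: the limit of > 1 h in this assay, at which 1 of the 4 values shown sits.

On these data alone, how far the 2-carboxyethyl chain lies past that limit stays open. So does the outcome of an amine or a longer ester chain at this place.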